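Quinoxaline sulfone anilines: amino-for-dimethoxy swap on fluoro core

The source may hold more compounds than are shown below. What is called first, only, known or untested is meant among the compounds shown, and "the series" means these compounds.

Measured compounds, with a functional assay on HL-60 cells (Homo sapiens) for cytotoxicity, read by MTT assay, with a stated time of 72 h; on this read-out lower numbers stand for stronger inhibition and higher numbers for weaker inhibition:
Compound 1 `COc1cc(Nc2nc3ccccc3nc2S(=O)(=O)c2ccccc2)cc(OC)c1`: 50 nM
Compound 2 `Nc1ccc(Nc2nc3ccccc3nc2S(=O)(=O)c2ccccc2)cc1`: 8720 nM
Compound 3 `COc1cc(Nc2nc3ccccc3nc2S(=O)(=O)c2ccc(F)cc2)cc(OC)c1`: 2360 nM

Compound 1 gives the lowest number of the three. The change 4-aminophenyl in place of 3,5-dimethoxyphenyl on a nitrogen on an aromatic ring produced a 170-fold higher number from compound 1 to compound 2 (2.24 log units; beyond the scatter). The other change, (fluoro in place of hydrogen on an aromatic carbon), produced a 47-fold higher number from compound 1 to compound 3 (1.67 log units; beyond the scatter). Both changes taken alone therefore move the read-out strongly in the same direction.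

Compound 4 `Nc1ccc(Nc2nc3ccccc3nc2S(=O)(=O)c2ccc(F)cc2)cc1` is not yet measured. Its core is that of compound 3, and the difference between compounds 3 and 4 is 4-aminophenyl in place of 3,5-dimethoxyphenyl on a nitrogen on an aromatic ring; the place is described in the same words as for compounds 1 and 2, so this is the same change seen from compound 1 to compound 2. Since the change is applied here on top of the fluoro-bearing core, whose own step from compound 1 was a 47-fold higher number from compound 1 to compound 3 (1.67 log units; beyond the scatter), compound 4 is expected to show a step of about a 25-fold higher number from compound 3 to compound 4 (1.41 log units; beyond the scatter), smaller than the earlier one on the assumption that two large losses do not add in full. The estimate for compound 4 is 60000 nM, within 15000 nM to 300000 nM, with a real chance that this assay reports only a limit.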

Compound 4, half-maximal inhibitory concentration: 1620 nM
Compound 4: the middle estimate sits 37-fold (1.57 log units) above what was measured; the measured number lies below the stated range.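

In this assay, 4-aminophenyl in place of 3,5-dimethoxyphenyl gives a 1.5-fold lower number from compound 3 to compound 4 (0.16 log units; within the scatter) on the fluoro-bearing core, so the large loss seen on the core of compound 1 does not carry over: the same change on two cores in this assay, a 170-fold higher number (2.24 log units; beyond the scatter) from compound 1 to compound 2 and a 1.5-fold lower number (0.16 log units; within the scatter) from compound 3 to compound 4, 250-fold (2.40 log units) apart, beyond the scatter of two such steps

Fluoro in place of hydrogen also depends on its partner, giving a 5.4-fold lower number from compound 2 to compound 4 (0.73 log units; beyond the scatter) with 4-aminophenyl present, opposite in direction to its step with 3,5-dimethoxyphenyl present: the same change on two cores in this assay, a 47-fold higher number (1.67 log units; beyond the scatter) from compound 1 to compound 3 and a 5.4-fold lower number (0.73 log units; beyond the scatter) from compound 2 to compound 4, 250-fold (2.40 log units) apart, beyond the scatter of two such steps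

The two changes therefore do not act independently within these four compounds, but this single set shows no cause and no rule for other cores, and compound 1 at 50 nM enters both comparisons.

As far as these compounds go, whether chloro in place of fluoro would also remove most of the advantage of 3,5-dimethoxyphenyl remains open. So does whether 4-methoxyphenyl in place of 4-aminophenyl would follow the same dependence on the core.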